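A few compounds are considered here, and "the series" means these few. Any claim that something is new, unique, unknown or untested is made for them only; others in the source may bear on it.

Measured compounds:
compound 1 `O=C([C@@H]1C[C@H]1c1ccccc1)N(CC1CCCNC1)c1ccc(-c2ccccc2)cc1` with 10 nM
compound 2 `CC[C@H](C)[C@H](N)CN(C(=O)[C@@H]1C[C@H]1c1cccc(F)c1)c1ccc(-c2ccccc2)cc1` with 560 nM

In a functional assay for agonist activity at G protein-coupled receptor 88 (Homo sapiens), read by HTRF and cAMP accumulation (on this read-out lower numbers stand for an effect already at smaller amounts and higher numbers for an effect only at larger amounts of compound), compound 2 stands at the higher of the two numbers, with compound 1 giving the lower one, and the gap between them lies beyond the scatter. Compound 3 `CC[C@H](C)[C@H](N)CN(C(=O)[C@@H]1C[C@H]1c1nc(C)cs1)c1ccc(-c2ccccc2)cc1` is not yet measured; it differs from compound 2 by 4-methyl-1,3-thiazol-2-yl in place of 3-fluorophenyl on a saturated ring carbon. For the measured compounds named here, no measured pair shows this change, so its size is unknown. A step of modest size in either direction is expected a 1.4-fold higher number from compound 2 to compound 3 (0.15 log units; within the scatter), with an outcome near the scatter as the most likely case. Compound 3 is estimated at 800 nM, within 200 nM to 3000 nM.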

Compound 3, half-maximal effective concentration: 730 nM
For compound 3 the middle estimate is 1.1-fold (0.04 log units) above the measured one; the range from low to high includes it.
By their numbers in this assay, from the lowest: compound 1; then compounds 2 and 3 (each within the scatter of the next).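

In this assay, 4-methyl-1,3-thiazol-2-yl in place of 3-fluorophenyl on a saturated ring carbon gives a 1.3-fold higher number from compound 2 to compound 3 (0.12 log units; within the scatter). At this position, therefore, a five-membered aromatic ring with 2 hetero atoms can stand in for a six-membered aromatic ring of carbon only without a change beyond the scatter. Nothing available explains this outcome.

From the compounds shown here alone, whether an amine, a carboxylic acid or a pyridine ring at this place would also stay within the scatter remains open. Compound 1 differs from compound 2 and compound 3 in more than one place, so its lower number cannot be tied to any single change.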